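The source may report more compounds than this note shows. Statements on the series, on what has been measured and on what is new or still open speak of the compounds shown alone.

Measured compounds:
- compound 1 `O=C(Nc1cccc(-c2oc3cc(-c4ccc(F)cc4)ccc3c(=O)c2O)c1)c1ccc(Cl)cc1`: 4730 nM
- compound 2 `O=C(Nc1cccc(-c2oc3cc(-c4ccc(F)cc4)ccc3c(=O)c2O)c1)c1ccc(C(F)(F)F)cc1`: 32600 nM
- compound 3 `COc1cccc(C(=O)Nc2cccc(-c3oc4cc(-c5ccc(F)cc5)ccc4c(=O)c3O)c2)c1`: 15300 nM

In a functional assay on MCF7 cells (Homo sapiens) for antiproliferative activity, read by CCK-8 assay, with a stated time of 72 h (on this read-out higher numbers stand for weaker inhibition and lower numbers for stronger inhibition), compound 3 stands second highest of these three numbers. Compound 1 gives the lowest number, and the step of a 3.2-fold higher number from compound 1 to compound 3 (0.51 log units; beyond the scatter) shows how much weaker compound 3 is. Compound 2 gives the highest number; the step of a 2.1-fold lower number from compound 2 to compound 3 (0.33 log units; beyond the scatter) shows compound 3 stronger than compound 2. The step of a 6.9-fold higher number from compound 1 to compound 2 (0.84 log units; beyond the scatter) frames the whole spread. All three steps change the group on the amide carbonyl, and each is modest.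

Compound 4 `COc1cc(OC)cc(C(=O)Nc2cccc(-c3oc4cc(-c5ccc(F)cc5)ccc4c(=O)c3O)c2)c1` differs from compound 3 by one change: methoxy in place of hydrogen on an aromatic carbon. Among the measured compounds shown here, no measured step adds a methoxy group to an aryl ring that already carries one, so the measured steps bear on it only loosely: changes on this aryl ring have so far moved the number by modest amounts in either direction. A step of similar size at most is therefore expected, a 1.0-fold lower number from compound 3 to compound 4 (0.01 log units; within the scatter), possibly none beyond the scatter. The estimate for compound 4 is 15000 nM, within a range from 5000 nM to 45000 nM.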

Compound 4, half-maximal inhibitory concentration: 3470 nM
Beside the measured number, compound 4's estimate is 4.3-fold (0.64 log units) above it; measured number outside the range, below it.
By their numbers in this assay, from the lowest: compounds 4 and 1 (each within the scatter of the next); then compound 3; then compound 2.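

In this assay, adding a second methoxy group to turn 3-methoxyphenyl into 3,5-dimethoxyphenyl gives a 4.4-fold lower number from compound 3 to compound 4 (0.64 log units; beyond the scatter), so this aryl ring responds clearly to an added group, and not only to the exchange of one group for another. The same ring gives a 9.4-fold lower number from compound 2 to compound 4 (0.97 log units; beyond the scatter), the largest step in this set, while a 1.4-fold lower number from compound 1 to compound 4 (0.13 log units; within the scatter) shows that 3,5-dimethoxyphenyl and 4-chlorophenyl sit level here, although they carry different groups. Nothing measured here explains why the added methoxy group has this effect.

On these data alone, whether an ethoxy group, a hydroxyl or an amine at the same place would match the methoxy group stays open. Also open, as far as these compounds go, is whether a methoxy group added to the 4-chlorophenyl ring would shift the number as it did for compound 4.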